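The source may hold more compounds than are shown below. What is called first, only, known or untested is meant among the compounds shown, and "the series" means these compounds.

Working notes on the series in a functional assay on MGC-803 cells (Homo sapiens) for inhibition, read by sulforhodamine B assay; a lower number here means a stronger inhibitor, a higher number a weaker inhibitor.

Compound 1, `O=C1C=C(Nc2ccc(C(F)(F)F)cc2)C(=O)c2c1nc1n2[C@H]2OC[C@@H](O)[C@H]2OC1`, gives 2820 nM in this assay. Compound 3, `CCOc1ccccc1NC1=CC(=O)c2c(nc3n2[C@H]2OC[C@@H](O)[C@H]2OC3)C1=O`, gives 2830 nM in this assay. Compound 1 holds the lowest of the two numbers, yet its gap to compound 3 is within the scatter, so neither can be ranked ahead of the other. Compound 2, `O=C1C(NC2CC2)=CC(=O)c2c1nc1n2[C@H]2OC[C@@H](O)[C@H]2OC1`, gives only a limit in this assay, > 4000 nM; a reading at this limit is the limit of > 4000 nM in this assay, at which 1 of the 3 values shown sits.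

For the measured compounds named here, the single step with a number at both ends is an at least 1.4-fold lower number from compound 2 to compound 3 (0.15 log units; that floor lies within the scatter), which replaces a cyclopropyl on the amine nitrogen by an aryl and gives a floor that is itself within the scatter.

Compound 4 is `O=C1C=C(Nc2cccc(Cl)c2)C(=O)c2c1nc1n2[C@H]2OC[C@@H](O)[C@H]2OC1`. Its change from compound 1 is 3-chlorophenyl in place of 4-(trifluoromethyl)phenyl on an amine nitrogen. Going by the values given here, no measured step here exchanges one aryl for another on that nitrogen, and the one aryl-to-aryl comparison in hand, compound 1 against compound 3, lies within the scatter. No step beyond the scatter is therefore expected in this assay. Compound 4 is expected near 2800 nM, with a range of 1300 nM to 6000 nM. The expected step is a 1.0-fold lower number from compound 1 to compound 4 (0.00 log units; within the scatter).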

Compound 4, half-maximal inhibitory concentration: 1770 nM
Compound 4: the middle estimate sits 1.6-fold (0.20 log units) above what was measured; low and high end bracket the measured number.
By their numbers in this assay, from the lowest: compounds 4, 1 and 3 (each within the scatter of the next). At a limit, above all of these: compound 2.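

For the compounds shown here, this gives the series its one printed step between two aryl groups on the amine nitrogen in this assay: a 1.6-fold lower number from compound 1 to compound 4 (0.20 log units; within the scatter). Exchanging 4-(trifluoromethyl)phenyl for 3-chlorophenyl alters both the substituent and its printed ring number, yet this pair gives no sign that the position separates these two aryl groups. No measurement in hand bears on a cause for this step.

The compounds shown do not separate the identity of the substituent from its ring number, a question that 4-chlorophenyl and 3-(trifluoromethyl)phenyl on the same nitrogen would address. Also open, going by these compounds, is how a phenyl carrying a carboxylic acid or an amine would read in this assay.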